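Carboxy for dimethylcarbamoyl: notes on compound 3

The source may hold more compounds than are shown below. What is called first, only, known or untested is meant among the compounds shown, and "the series" means these compounds.

Measured in a toxicity assay on CCRF-CEM cells (Homo sapiens) for cytotoxicity; on this read-out lower numbers stand for higher toxicity in this test and higher numbers for lower toxicity in this test:
- compound 1 (`CN(C)c1cccc2c1nc(-c1c(F)cccc1F)n2Cc1c(F)cccc1F`) gives > 100 uM (a limit of the assay)
- compound 2 (`CN(C)C(=O)c1cccc2c1nc(-c1c(F)cccc1F)n2Cc1c(F)cccc1F`) gives 80.1 uM

For the measured compounds named here, compound 2 holds the only actual number in this assay. The change to compound 3 (`O=C(O)c1cccc2c1nc(-c1c(F)cccc1F)n2Cc1c(F)cccc1F`) is hydroxy in place of dimethylamino on a carbonyl carbon. Going by the values given here, the only measured step is an at least 1.2-fold lower number from compound 1 to compound 2 (0.09 log units; that floor lies within the scatter). Among the compounds with values here, it introduces the dimethylcarbamoyl now replaced, but no measured compound carries carboxy, so it bears only loosely. The expected change is no larger than the scatter, a slightly higher number at most, and the estimated step is a 1.2-fold higher number from compound 2 to compound 3 (0.07 log units; within the scatter). Compound 3 is estimated at 95 uM, with an expected range of 45 uM to 200 uM.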

Compound 3, half-maximal toxic concentration: 23.5 uM
Compound 3: middle estimate off by 4.0-fold (0.61 log units), on the high side; the measured number lies below the stated range.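

In this assay, for the compounds shown here, this position is sensitive to the group on the carbonyl carbon: hydroxy in place of dimethylamino gives a 3.4-fold lower number from compound 2 to compound 3 (0.53 log units; beyond the scatter), the first step beyond the scatter. Carboxy in place of dimethylamino on the aromatic carbon gives an at least 4.2-fold lower number from compound 1 to compound 3 (0.62 log units; beyond the scatter). That step is only a floor, since compound 1 stands at a limit of the assay: the limit of > 100 uM in this assay, at which 1 of the 3 values shown sits.

A primary amide or a methyl ester at this place would show whether the lower number needs the free carboxylic acid. On these data alone, a longer chain carrying the carboxylic acid remains open too.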